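Fluoro for Methoxy on the Anilino Ring of a Shared Core

This account rests on a few compounds, and the source may have more. Where it says the series, first, only, none or still open, it means among the compounds named here.

Three compounds share one core. Compound 1 is `O=C(/C=C\Nc1ccc(F)cc1)c1nc(-c2ccc(F)cc2)n2ccccc12` and compound 2 is `COc1ccc(N/C=C\C(=O)c2nc(-c3ccc(OC)cc3)n3ccccc23)cc1`. In a functional assay on A549 cells (Homo sapiens) for cytotoxicity, read by MTT assay, with a stated time of 48 h (on this read-out lower numbers stand for stronger inhibition and higher numbers for weaker inhibition), compound 1 gives 13200 nM. In this assay compound 2 gives "not determined" (no result reported), so where it stands cannot be read from any number. Compound 3, `COc1ccc(-c2nc(C(=O)/C=C\Nc3ccc(F)cc3)c3ccccn23)cc1`, has not yet been measured. It differs from compound 2 in one place: fluoro in place of methoxy on an aromatic carbon. For the measured compounds named here, no step between two measured compounds is available to show how large a change of this kind is in this assay, or in which direction it runs. Because compound 1 gives 13200 nM while carrying the same (4-fluorophenyl)amino part, compound 3 is expected to come out near that level, with no shift beyond the scatter foreseen. Compound 3 is therefore estimated at about 11000 nM, between 3500 nM and 35000 nM.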

Compound 3, half-maximal inhibitory concentration: > 30000 nM
Compound 3 was reported as a limit (the forecaster's own chance of this, stated with the estimate: 25%); middle value at least 2.7-fold (0.43 log units) from the limit.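

In this assay compound 3 gives > 30000 nM, which is a limit of the assay and not a number. For the compounds shown here, this yields the first readable step for a swap of this kind: replacing 4-fluorophenyl on the shared core with 4-methoxyphenyl, while (4-fluorophenyl)amino stays in place, gives an at least 2.2-fold higher number from compound 1 to compound 3 (0.35 log units; beyond the scatter), so methoxy at this position goes with weaker inhibition than fluoro. The step gives a direction and a minimum size, but its full size stays hidden: the limit of > 30000 nM in this assay, at which 1 of the 3 values shown sits.

On these data alone, the step from compound 2 to compound 3 cannot be read, so the same swap on the anilino ring remains unsized, and its direction remains unknown. Also open, as far as these compounds go, is how an amine, a carboxylic acid or a longer chain such as ethoxy would fare on the aromatic carbon that carries methoxy in compound 3.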